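From acetoxy to (propylcarbonyl)oxy on compound 2

A few compounds are considered here, and "the series" means these few. Any claim that something is new, unique, unknown or untested is made for them only; others in the source may bear on it.

Values in a functional assay on LFCl2A cells (Rattus norvegicus) for cytotoxicity; a lower number here means a stronger inhibitor, a higher number a weaker inhibitor:
- compound 1 `CCCCCCCC/C=C\CCCCCCCC(=O)OC[C@H]1O[C@H](CC2=CCCCC2)C=CC1=O`: 80 nM
- compound 2 `CC(=O)OC[C@H]1O[C@H](C2CCCC=C2C)C=CC1=O`: 700 nM
- compound 3 `CC/C=C\C/C=C\C/C=C\C/C=C\C/C=C\C/C=C\CCC(=O)OC[C@@H]1C=CC(=O)[C@@H](C2CCCC=C2C)O1`: 65000 nM

Among these three compounds, compound 2 (700 nM) holds the middle place, with the second highest number in this assay. Compound 1 (80 nM) lies lower and compound 3 (65000 nM) lies higher, both beyond the scatter of compound 2.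

Compound 4 `CCCC(=O)OC[C@H]1O[C@H](C2CCCC=C2C)C=CC1=O` has not yet been measured. It comes from compound 2 through a single change (ethyl in place of hydrogen on a saturated chain carbon bound to a carbonyl carbon), so that acetoxy becomes (propylcarbonyl)oxy.

Among the compounds with values here, no measured pair isolates a change of this kind. Compound 1 and compound 3 each differ from compound 2 in more than one place, and they fall on opposite sides of it, so they suggest no direction. An estimated 1.1-fold higher number from compound 2 to compound 4 (0.06 log units; within the scatter) is therefore expected to stay within the scatter. The estimate for compound 4 is an expected 800 nM with a likely range from 250 nM to 2800 nM as the expected span.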

Compound 4, half-maximal inhibitory concentration: 350 nM
Estimate against measurement, compound 4: 2.3-fold (0.36 log units) above; the measured number falls inside the stated range.
By their numbers in this assay, from the lowest: compound 1; then compounds 4 and 2 (each within the scatter of the next); then compound 3.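

In this assay, the step that isolates this position reads a 2.0-fold lower number from compound 2 to compound 4 (0.30 log units; within the scatter) and so shows that replacing hydrogen with ethyl on a saturated chain carbon bound to a carbonyl carbon, which turns acetoxy into (propylcarbonyl)oxy, leaves the number within the usual scatter. Compound 1 and compound 3 each differ from compound 2 in more than one place, so neither could show this for a single change. No independent measurement bears on why the step came out this way.

The compounds shown leave open whether an amine or a carboxylic acid in place of ethyl at this place would also stay within the scatter of compound 2. They also leave open whether ethyl would give a similar step on the core of compound 1.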